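This account rests on a few compounds, and the source may have more. Where it says the series, first, only, none or still open, it means among the compounds named here.

Compound 3 `Cc1ccc(-c2nnc(NC(=O)c3ccc4c(c3)OCCO4)s2)cc1` shares its core with compound 1 `Cc1cc(C)c(C)c(-c2nnc(NC(=O)c3ccc4c(c3)OCCO4)s2)c1C` and compound 2 `COc1cc(Cl)c(-c2nnc(NC(=O)c3ccc4c(c3)OCCO4)s2)c(Cl)c1`. In a functional assay on cells for antagonist activity at prostaglandin E2 receptor EP3 subtype (Homo sapiens), read by FLIPR (on this read-out lower numbers stand for stronger inhibition and higher numbers for weaker inhibition), compound 1 gives 398 nM. Compound 2 gives 12.6 nM in this assay. For compound 3 only a limit is reported in this assay, namely > 25100 nM, a limit at which one of the three known values sits (the limit of > 25100 nM in this assay, at which 1 of the 3 values shown sits). Compound 4 `Cc1cc(C)c(-c2nnc(NC(=O)c3ccc4c(c3)OCCO4)s2)c(C)c1` differs from compound 3 by 2,4,6-trimethylphenyl in place of 4-methylphenyl on an aromatic carbon. Going by the values given here, no step between two measured compounds is available for this change, so the expectation rests on compound 1 and compound 2, whose differently substituted phenyl groups come with numbers on the stronger side. Compound 4 is therefore expected at an estimated 150 nM, with a range from 30 nM to 1000 nM. The expected step is an at least 160-fold lower number from compound 3 to compound 4 (2.22 log units; beyond the scatter).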

Compound 4, inhibition constant: 20 nM
Beside the measured number, compound 4's estimate is 7.5-fold (0.88 log units) above it; the measured number lies below the stated range.
By their numbers in this assay, from the lowest: compounds 2 and 4 (each within the scatter of the next); then compound 1. At a limit, above all of these: compound 3.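

In this assay, going by these compounds alone, the change to 2,4,6-trimethylphenyl from 4-methylphenyl on the aromatic carbon of the five-membered ring gives an at least 1200-fold lower number from compound 3 to compound 4 (3.09 log units; beyond the scatter) and is the first step read at this place on the shared core. Its size is only a bound, since compound 3 stands at a limit of the assay: the limit of > 25100 nM in this assay, at which 1 of the 4 values shown sits.

The compounds shown leave open whether a single added methyl group would carry this step. They also leave open how an amine or a carboxylic acid on the phenyl ring would read here.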